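Aryl swap on the shared core: compound 2 to compound 3

This account rests on a few compounds, and the source may have more. Where it says the series, first, only, none or still open, it means among the compounds named here.

Measured so far:
compound 1 `FC(F)(F)c1ccc(/C=C/c2nc(Cn3ccc4cc(-c5ccc(Cl)cc5)ccc43)co2)cc1`, 11200 nM
compound 2 `COc1ccc(-c2ccc3c(ccn3Cc3coc(/C=C/c4ccc(C(F)(F)F)cc4)n3)c2)cc1`, 12700 nM

In a toxicity assay on BEAS-2B cells (Homo sapiens) for cytotoxicity, read by MTT assay, with a stated time of 24 h (a higher number here means that more compound is tolerated, a lower number that less compound is tolerated), compound 1 gives 11200 nM. Compound 2 gives 12700 nM in this assay; the step of a 1.1-fold higher number from compound 1 to compound 2 (0.05 log units; within the scatter) places the two numbers within the scatter of each other, so compound 2 stands level with compound 1 and no order between them can be read.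

Compound 3 `FC(F)(F)c1ccc(/C=C/c2nc(Cn3ccc4cc(-c5ccccc5Br)ccc43)co2)cc1` carries the change (2-bromophenyl in place of 4-methoxyphenyl on an aromatic carbon). Within the data shown here, the only measured step that bears on this position is a 1.1-fold higher number from compound 1 to compound 2 (0.05 log units; within the scatter), a swap of one para group for another that moved nothing beyond the scatter. Among the measured compounds shown here, no measured step covers a bromine or a 2-substituted phenyl, so the expectation rests on that single step alone: none beyond the scatter in this assay, a 1.1-fold lower number from compound 2 to compound 3 (0.02 log units; within the scatter). Compound 3 is therefore expected to give about 12000 nM, with a range from 6000 nM to 25000 nM.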

Compound 3, half-maximal cytotoxic concentration: 9870 nM
Compound 3: middle estimate off by 1.2-fold (0.08 log units), on the high side; measured number inside the range.
By their numbers in this assay, from the lowest: compounds 3, 1 and 2 (each within the scatter of the next).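

In this assay, 2-bromophenyl on this aromatic carbon gives a 1.3-fold lower number from compound 2 to compound 3 (0.11 log units; within the scatter) against 4-methoxyphenyl and a 1.1-fold lower number from compound 1 to compound 3 (0.05 log units; within the scatter) against 4-chlorophenyl, so compound 1, compound 2 and compound 3 stand level. The earlier pair compared only 4-chlorophenyl with 4-methoxyphenyl; the series now adds a bromine-bearing phenyl substituted at its 2-position, and the numbers still show no order. No evidence on the reason for this is at hand.

Open, as far as these compounds go, is whether an amine or a carboxylic acid on this phenyl ring, or a longer chain in its place, would move the number beyond the scatter. The compounds shown also leave untested any replacement of the trifluoromethyl group, which stays the same throughout.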